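Swapping a Carboxy Group in an Analgesic Series

The source may report more compounds than this note shows. Statements on the series, on what has been measured and on what is new or still open speak of the compounds shown alone.

compound 1, `CSCC[C@H](NC(=O)CN(c1ncnc2c1ncn2C1CCCCO1)C1CC1)C(=O)OCc1ccccc1`: 17.5%
compound 2, `CC(C)[C@H](NC(=O)CN(c1nc(Cl)nc2[nH]cnc12)C1CC1)C(=O)OCc1ccccc1`: 17.9%
compound 3, `O=C(O)CC[C@H](NC(=O)CN(c1nc(Cl)nc2[nH]cnc12)C1CC1)C(=O)O`: 29.5%

In a functional assay on the whole organism (Tail, strain ICR) with Mus musculus as the target, in the tail flick test, with a stated time of 150 min, at a dose of 25 umol/kg by the oral route (on this read-out lower numbers stand for a weaker effect and higher numbers for a stronger effect at the one dose given), compound 3 stands highest of the three measured compounds; its gaps to compound 2 and to compound 1 both lie beyond the usual scatter, so it is the most active of them. Compound 4 `N=C(N)NCCC[C@H](NC(=O)CN(c1nc(Cl)nc2[nH]cnc12)C1CC1)C(=O)O` has not yet been measured. It differs from compound 3 in one place: a group of 5 heavy atoms (2 carbon, 3 nitrogen; no ring) in place of a group of 3 heavy atoms (1 carbon, 2 oxygen; no ring), on a saturated chain carbon, three bonds along the chain from an amide-type nitrogen and a carbonyl carbon. Among the compounds with values here, no pair of measured compounds shows this change by itself, so nothing in the data tells how large a step to expect; the expected step in this assay is none beyond the scatter, in either direction. The estimate for compound 4 is 30%, with a range from 15% to 45%. This expectation means a step of a number 0.5 percentage points higher from compound 3 to compound 4 (within the scatter).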

Compound 4, a percentage reported as activity, at one dose (the size of the read-out at that dose, not a potency): 7.19%
Beside the measured number, compound 4's estimate is 22.8 percentage points above it; measured number below the stated range.
By their numbers in this assay, from the lowest: compound 4; then compounds 1 and 2 (each within the scatter of the next); then compound 3.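

In this assay putting the group of 5 heavy atoms (2 carbon, 3 nitrogen; no ring) in place of the carboxy group gives a number 22.3 percentage points lower from compound 3 to compound 4 (beyond the scatter) at the one dose tested. The effect at this dose therefore depends on what sits on this saturated chain carbon, and the carboxy group cannot be exchanged here without a change in the read-out. Nothing measured on these compounds gives a reason for the step.

An amine or a primary amide at this place remains untested among the compounds shown. Going by these compounds, whether either would stay near compound 3 or fall towards compound 4 stays open.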